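The source may report more compounds than this note shows. Statements on the series, on what has been measured and on what is new or still open speak of the compounds shown alone.

Series notes. Compound 1 `CCOC(=O)C1=Cc2ccccc2OC1(OCc1cn(-c2ccc(F)cc2)nn1)C(F)(F)F` gives 9100 nM in a functional assay on MCF7 cells (Homo sapiens) for inhibition, read by MTT assay, with a stated time of 24 h; a higher number here means a weaker inhibitor, a lower number a stronger inhibitor. Compound 3 `CCOC(=O)C1=Cc2ccccc2OC1(OCc1cn(-c2ccc([N+](=O)[O-])cc2)nn1)C(F)(F)F` returns only > 150000 nM in this assay, a limit of the assay rather than a number. Among the measured compounds shown here, the single measured step on this aromatic carbon is an at least 16-fold higher number from compound 1 to compound 3 (1.21 log units; beyond the scatter). Compound 2 `CCOC(=O)C1=Cc2ccccc2OC1(OCc1cc(-c2ccc(OC)cc2)no1)C(F)(F)F` likewise sits at > 150000 nM in this assay, a limit and not a number, so its standing is known only through (the limit of > 150000 nM in this assay, at which 2 of the 3 values shown sit). Compound 4 `CCOC(=O)C1=Cc2ccccc2OC1(OCc1cc(-c2ccc(F)cc2)no1)C(F)(F)F` differs from compound 2 by fluoro in place of methoxy on an aromatic carbon. For the measured compounds named here, no measured step covers this exchange; compound 1 and compound 3 show only that the group on this carbon can move the number by a large amount. Compound 4 is therefore expected near 60000 nM, between 8000 nM and 150000 nM, an expected step of an at least 2.5-fold lower number from compound 2 to compound 4 (0.39 log units; beyond the scatter), with a real chance of another limit.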

Compound 4, half-maximal inhibitory concentration: 48200 nM
Estimate against measurement, compound 4: 1.2-fold (0.10 log units) above; the range from low to high includes it.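

In this assay, 4-methoxyphenyl to 4-fluorophenyl gives an at least 3.1-fold lower number from compound 2 to compound 4 (0.49 log units; beyond the scatter), so the group on this aromatic carbon also moves the number in the series of compound 2, not only in that of compound 1. In both pairs shown, the fluoro member gives a measured number and its partner stands at a limit. The step therefore remains a lower bound: the limit of > 150000 nM in this assay, at which 2 of the 4 values shown sit.

Open, on these data alone, is how an amine or a longer alkoxy chain on this carbon would read. Also open, as far as these compounds go, is whether the fluoro compounds keep their numbers with a carboxylic acid in place of the ethyl ester.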